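Two inactive analogues and an unmeasured benzyl variant

The source may hold more compounds than are shown below. What is called first, only, known or untested is meant among the compounds shown, and "the series" means these compounds.

Measured in a functional assay on PC-3 cells (Homo sapiens) for cytotoxicity; a lower number here means a stronger inhibitor, a higher number a weaker inhibitor:
- compound 1, `Oc1[nH]nc2nnc(-c3ccccc3)c(-c3ccccc3)c12`: > 100000 nM
- compound 2, `Nc1nn(COCCO)c2nnc(-c3ccccc3)c(-c3ccccc3)c12`: > 100000 nM

Compound 1 sits at a limit in this assay and gives no number. Compound 2 likewise sits at a limit in this assay rather than at a number. Going by the values given here, both values shown therefore stand at the same place, (the limit of > 100000 nM in this assay, at which 2 of the 2 values shown sit), and no step between two measured compounds can be read off; compound 2 stands at the limit with nothing on either side of it.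

Compound 3, `Nc1nn(Cc2ccccc2)c2nnc(-c3ccccc3)c(-c3ccccc3)c12`, has not been measured. It differs from compound 2 in one place: phenyl in place of 2-hydroxyethoxy on a saturated chain carbon bound to an aromatic nitrogen. The change is on the saturated chain carbon bound to the aromatic nitrogen, where the 2-hydroxyethoxy group of compound 2 is replaced by phenyl.

Among the compounds with values here, with no measured step to lean on, the step expected from compound 2 to compound 3 in this assay is none beyond the scatter, a number no higher from compound 2 to compound 3 (the limit leaves the size open); most likely compound 3 also ends at a limit. For compound 3 the estimate in this assay is 100000 nM, with a range of 30000 nM to 300000 nM.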

Compound 3, half-maximal inhibitory concentration: > 100000 nM
Compound 3 was reported as a limit; the forecaster's own chance of this, stated with the estimate: 80%; the middle value sits exactly at the limit.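

In this assay compound 3 gives > 100000 nM, a limit and not a number. Going by these compounds alone, no step from compound 2 to compound 3 can be read, as the values stand together at one limit: the limit of > 100000 nM in this assay, at which 3 of the 3 values shown sit. The compounds shown leave open whether any change on the shared core brings a readable number in this assay.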